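Thiourea series: nitro to amino on the aryl ring

The source may report more compounds than this note shows. Statements on the series, on what has been measured and on what is new or still open speak of the compounds shown alone.

Measured so far:
- compound 1, `C[C@@H](/N=C(\S)NCc1ccc(C(C)(C)C)cc1)c1ccc([N+](=O)[O-])cc1` — > 100000 nM
- compound 2, `C[C@H](/N=C(\S)NCc1ccc(C(C)(C)C)cc1)c1ccc([N+](=O)[O-])cc1` — > 100000 nM
- compound 3, `CCC(/N=C(\S)NCc1ccc(C(C)(C)C)cc1)c1ccc(NS(C)(=O)=O)cc1` — > 100000 nM

In a functional assay with Rattus norvegicus as the target (on this read-out lower numbers stand for an effect already at smaller amounts and higher numbers for an effect only at larger amounts of compound), compound 1 gives only a limit, > 100000 nM. Compound 2 likewise reaches only a limit, > 100000 nM. Compound 3 also stops at a limit, > 100000 nM. Hence (the limit of > 100000 nM in this assay, at which 3 of the 3 values shown sit). Among the measured compounds shown here, the one step between measured compounds, a step that the two limits leave unreadable from compound 1 to compound 2, is left unreadable by both limits, although (the fact that compounds 1 and 2 differ only in the configuration as drawn). Compound 4, `C[C@@H](/N=C(\S)NCc1ccc(C(C)(C)C)cc1)c1ccc(N)cc1`, is not yet measured; it differs from compound 1 by amino in place of nitro on an aromatic carbon. For the measured compounds named here, no measured step bears on this change, and no measured value of the series lies inside the readable range of this assay. The expectation therefore rests on compound 1 alone, whose value is a limit. Compound 4 is expected near 100000 nM, between 20000 nM and 300000 nM. The expected step is a number no higher from compound 1 to compound 4 (the limit leaves the size open), most likely again reported as a limit.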

Compound 4, half-maximal effective concentration: > 100000 nM
Compound 4 ended at the assay's limit; the forecaster's own chance of this, stated with the estimate: 70%; the middle value sits exactly at the limit.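

The step from compound 1 to compound 4, amino in place of nitro, cannot be read: both values are limits. The compounds shown leave open how this change, or any other in the series, would register within the readable range of this assay.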